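A few compounds are considered here, and "the series" means these few. Any claim that something is new, unique, unknown or untested is made for them only; others in the source may bear on it.

Compound 3, `COc1ccc(-c2cc3c(OC)cc(OC)cc3n(CCCC#N)c2=O)cc1`, stands level with compounds 1 and 2 in a functional assay on T47D cells (Homo sapiens) for cytotoxicity, read by colorimetric assay and MTT assay; on this read-out lower numbers stand for stronger inhibition and higher numbers for weaker inhibition. Compound 1, `CCOC(=O)Cn1c(=O)c(-c2ccc(OC)cc2)cc2c(OC)cc(OC)cc21`, gives 10000 nM in this assay, and compound 2, `CCN(CC)C(=O)Cn1c(=O)c(-c2ccc(OC)cc2)cc2c(OC)cc(OC)cc21`, gives 10000 nM. Compound 3 gives 10000 nM. The three steps that connect them leave the read-out where it is: no change at the digits printed from compound 1 to compound 2 (within the scatter), no change at the digits printed from compound 1 to compound 3 (within the scatter), and no change at the digits printed from compound 2 to compound 3 (within the scatter). Each of these changes the chain on the aromatic nitrogen without moving the number beyond the scatter.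

Compound 4, `COc1ccc(-c2cc3c(OC)cc(OC)cc3n(CC(=O)OCc3ccccc3)c2=O)cc1`, takes the same chain in a new direction: benzyloxycarbonyl in place of 2-cyanoethyl on a saturated chain carbon bound to an aromatic nitrogen. The steps from compound 1 to compound 3 and from compound 2 to compound 3 bear most directly on it, since each exchanged a carbonyl-bearing chain for the 2-cyanoethyl chain, and neither produced a change at the digits shown; compound 4 reverses that exchange with a benzyloxycarbonyl group in place of the nitrile chain. On this evidence the step from compound 3 to compound 4 is expected to be no change at the digits printed from compound 3 to compound 4 (within the scatter), that is, no movement beyond the scatter. The value expected for compound 4 in this assay is therefore 10000 nM, within a range from 5000 nM to 20000 nM.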

Compound 4, half-maximal inhibitory concentration: 10000 nM
Estimate against measurement, compound 4: no gap at the digits printed, and the stated range covers the measured number.
By their numbers in this assay, from the lowest: compounds 1, 2, 3 and 4 (each within the scatter of the next).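

In this assay the chain on the aromatic nitrogen carries a six-membered aromatic ring of carbon only, which the chains of compounds 1, 2 and 3 lack, and exchanging 2-cyanoethyl for benzyloxycarbonyl gives no change at the digits printed from compound 3 to compound 4 (within the scatter) at this position. The carbonyl-bearing chains tell the same story: phenyl in place of methyl on a saturated chain carbon bound to an oxygen next to a carbonyl group gives no change at the digits printed from compound 1 to compound 4 (within the scatter) and benzyloxy in place of diethylamino on a carbonyl carbon gives no change at the digits printed from compound 2 to compound 4 (within the scatter) so this position has now taken a nitrile, an amide, and two esters, one of them bearing the aromatic ring, with no step beyond the scatter. No measurement is available that could explain why the read-out stays put across these changes.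

From the compounds shown here alone, whether a carboxylic acid or a tertiary amine at the end of this chain would leave the read-out equally unmoved remains open. So does the effect of a hydroxyl in place of a methoxy on the shared core, since all four compounds keep that core unchanged.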